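From tert-butoxycarbonyl to an oxadiazole on a ring amine

A few compounds are considered here, and "the series" means these few. Any claim that something is new, unique, unknown or untested is made for them only; others in the source may bear on it.

Compound 2 `CC(C)(C)OC(=O)N1CCC(CCCNc2ccc3c(c2)C(=O)CC3)CC1` was tested in a functional assay on CHO-K1 cells for agonist activity at Glucose-dependent insulinotropic receptor (Homo sapiens), read by HTRF and cAMP accumulation, with a stated time of 30 min (on this read-out higher numbers stand for an effect only at larger amounts of compound and lower numbers for an effect already at smaller amounts), where compound 2 gives 46 nM. Compound 1 `CCc1cnc(N2CCC(CCCNc3ccc4c(c3)C(=O)CC4)CC2)nc1` gives 51 nM in this assay, and the step of a 1.1-fold lower number from compound 1 to compound 2 (0.04 log units; within the scatter) shows that these two numbers sit within the scatter of each other. Compound 3 `COc1cnc(N2CCC(CCCNc3ccc4c(c3)OCC4=O)CC2)nc1` gives 115 nM, a number lying beyond the scatter of compound 2. In compound 4 `CC(C)c1noc(N2CCC(CCCNc3ccc4c(c3)C(=O)CC4)CC2)n1` the change is 3-isopropyl-1,2,4-oxadiazol-5-yl in place of tert-butoxycarbonyl on an amine nitrogen in a ring. Among the compounds with values here, the only measured step touching this position, a 1.1-fold lower number from compound 1 to compound 2 (0.04 log units; within the scatter), exchanged 5-ethylpyrimidin-2-yl for tert-butoxycarbonyl without a shift beyond the scatter, so the exchange of tert-butoxycarbonyl for another aromatic heterocycle is expected to give a 1.1-fold higher number from compound 2 to compound 4 (0.04 log units; within the scatter), a step within the scatter. Compound 4 is therefore estimated at 50 nM, with a range from 20 nM to 130 nM.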

Compound 4, half-maximal effective concentration: 58 nM
Compound 4: the middle estimate sits 1.2-fold (0.06 log units) below what was measured, and the stated range covers the measured number.
By their numbers in this assay, from the lowest: compounds 2, 1, 4 and 3 (each within the scatter of the next, the first and the last beyond it).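

In this assay the 3-isopropyl-1,2,4-oxadiazol-5-yl group brings a 1.3-fold higher number from compound 2 to compound 4 (0.10 log units; within the scatter) against tert-butoxycarbonyl and a 1.1-fold higher number from compound 1 to compound 4 (0.06 log units; within the scatter) against 5-ethylpyrimidin-2-yl on the amine nitrogen in a ring. A five-membered aromatic ring with 3 hetero atoms thus joins the two earlier groups at this position, and all three give numbers within the scatter of each other. Nothing at hand gives a reason for this.

Open, from the compounds shown here alone, is whether this nitrogen would keep such numbers with only a hydrogen or a methyl on it. Also open, going by these compounds, is what a carboxylic acid in place of the isopropyl on the oxadiazole would do.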